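The source may hold more compounds than are shown below. What is called first, only, known or untested is meant among the compounds shown, and "the series" means these compounds.

Compound 1 `O=C(c1ccncc1)N1N=C(c2cc3ccccc3o2)CC1c1cccc([N+](=O)[O-])c1` in an ADME assay on Vero cells (Chlorocebus sabaeus) for cytotoxicity, read by MTT assay, with a stated time of 72 h (on this read-out lower numbers stand for stronger inhibition and higher numbers for weaker inhibition), gives > 240000 nM, which is a limit of the assay rather than a number.
Compound 2 `O=C(c1ccncc1)N1N=C(c2cc3ccccc3o2)CC1c1ccccc1[N+](=O)[O-]` gives > 245000 nM, also a limit.
Compound 3 `COc1ccc(C2CC(c3cc4ccccc4o3)=NN2C(=O)c2ccncc2)cc1` gives > 200000 nM, again a limit.

Compound 3 thus stands at a limit, and the two other values are limits as well. Compound 4 `O=C(c1ccncc1)N1N=C(c2cc3ccccc3o2)CC1/C=C/c1ccccc1` differs from compound 3 in one place: 2-phenylethenyl in place of 4-methoxyphenyl on a saturated ring carbon. The measured steps that bear on this change are a step that the two limits leave unreadable from compound 1 to compound 3 and a step that the two limits leave unreadable from compound 2 to compound 3; since every value is a limit, as the limit of > 200000 nM in this assay, at which 1 of the 3 values shown sits, the limit of > 240000 nM in this assay, at which 1 of the 3 values shown sits, and the limit of > 245000 nM in this assay, at which 1 of the 3 values shown sits, show, neither step is readable and none can set a size or a direction. With no readable step, compound 4 is expected to sit near the same limit, and a step that the limit leaves unreadable from compound 3 to compound 4 is expected to stay within the scatter. Compound 4 is estimated at 250000 nM, from 100000 nM to 400000 nM.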

Compound 4, half-maximal inhibitory concentration: > 212000 nM
Compound 4: no number, only a limit; the forecaster's own chance of this, stated with the estimate: 85%; the middle value does not contradict the limit.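

Compound 4 also stands at a limit, as do compound 1, compound 2 and compound 3, so none of the steps to compound 4 can be read. Left open is the actual value of each compound in this assay, and whether the group on the saturated ring carbon changes it at all.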